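Acid series: ether replacement for the pyridinyl arm

This account rests on a few compounds, and the source may have more. Where it says the series, first, only, none or still open, it means among the compounds named here.

Values in an assay for inhibition of inositol hexakisphosphate kinase 3 (Homo sapiens), read by colorimetric assay, coupled enzyme assay and malachite green, with a stated time of 120 min, in the presence of a further agent that is not named here (on this read-out lower numbers stand for stronger inhibition and higher numbers for weaker inhibition), for the measured compounds:
compound 1, `CNC(=O)/C=C/c1ccc2noc(-c3ccccc3)c2c1`: 42600 nM
compound 2, `O=C(O)/C=C/c1ccc2noc(-c3ccc(OC(F)(F)F)cc3)c2c1`: 8370 nM
compound 3, `O=C(O)c1ccc2noc(-c3ccc(-c4ccncc4)cc3)c2c1`: 670 nM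

Compound 3 has the lowest number of the three; compound 2 stands at a higher number beyond the scatter, and compound 1 at a higher number further still. No pair among these differs in one place, so only the bare values can be compared.

Compound 4, `O=C(O)c1ccc2noc(-c3ccc(Oc4ncc(Cl)cc4Cl)cc3)c2c1`, is compound 3 with (3,5-dichloropyridin-2-yl)oxy in place of pyridin-4-yl on an aromatic carbon. The change sits at the far end of the molecule and the acid is kept. Going by the values given here, with no comparable step measured, a small shift toward higher numbers is expected, a 2.2-fold higher number from compound 3 to compound 4 (0.35 log units; beyond the scatter), close to the scatter. Compound 4 is estimated at 1500 nM, within 300 nM to 8000 nM.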

Compound 4, half-maximal inhibitory concentration: 2250 nM
Estimate against measurement, compound 4: 1.5-fold (0.18 log units) below; the range from low to high includes it.
By their numbers in this assay, from the lowest: compound 3; then compound 4; then compound 2; then compound 1.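

The far end of the molecule accepts an oxygen-linked arm with the acid kept: (3,5-dichloropyridin-2-yl)oxy in place of pyridin-4-yl on an aromatic carbon costs only a modest step (a 3.4-fold higher number from compound 3 to compound 4 (0.53 log units; beyond the scatter)). The swap alters the linking oxygen, the ring attachment and both chlorines at once, so no single part can be credited. No supporting data bear on the reason for this step. Open, going by these compounds, is how an unsubstituted phenoxy arm or an aminomethyl group would read at this place, and whether the step carries over to the longer acid chain of compound 2.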